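The source may hold more compounds than are shown below. What is called first, only, known or untested is meant among the compounds shown, and "the series" means these compounds.

Values measured in a functional assay on HeLa cells (Homo sapiens) for inhibition, read by sulforhodamine B assay (on this read-out higher numbers stand for weaker inhibition and lower numbers for stronger inhibition), are as follows.
- Compound 1 `O=C1C(NC2CCCC2)=CC(=O)c2c1nc1n2[C@H]2OC[C@@H](O)[C@H]2OC1` gives > 16000 nM as a limit of the assay, not a number.
- Compound 2 `Cc1ccc(NC2=CC(=O)c3c(nc4n3[C@H]3OC[C@@H](O)[C@H]3OC4)C2=O)cc1` gives 6590 nM here.
- Compound 3 `CCc1ccc(NC2=CC(=O)c3nc4n(c3C2=O)[C@H]2OC[C@@H](O)[C@H]2OC4)cc1` gives 3990 nM here.

Compound 3 (3990 nM) and compound 2 (6590 nM) lie within the usual scatter of each other, so these two cannot be ranked in this assay on these numbers. The next analogue, compound 4 `CCOc1ccc(NC2=CC(=O)c3nc4n(c3C2=O)[C@H]2OC[C@@H](O)[C@H]2OC4)cc1`, is still unmeasured. It carries ethoxy in place of ethyl on an aromatic carbon, para to a large group ethoxy in place of ethyl on an aromatic carbon and thus turns 4-ethylphenyl into 4-ethoxyphenyl.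

Going by the values given here, the only measured step (an at least 2.4-fold lower number from compound 1 to compound 2 (0.38 log units; beyond the scatter)) replaces cyclopentyl with 4-methylphenyl on an amine nitrogen, a change of a different kind, so it bears only loosely. The nearer guide is the 4-methylphenyl and 4-ethylphenyl pair, whose values stay within the scatter. No step beyond the scatter is therefore expected in this assay in either direction. The expected change is small (a 1.0-fold higher number from compound 3 to compound 4 (0.00 log units; within the scatter)). Compound 4 is estimated at 4000 nM (expected range 1800 nM to 9000 nM).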

Compound 4, half-maximal inhibitory concentration: 3110 nM
For compound 4 the middle estimate is 1.3-fold (0.11 log units) above the measured one; low and high end bracket the measured number.
By their numbers in this assay, from the lowest: compounds 4, 3 and 2 (each within the scatter of the next, the first and the last beyond it). At a limit, above all of these: compound 1.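

In this assay, ethoxy in place of ethyl on an aromatic carbon, para to a large group, gives a 1.3-fold lower number from compound 3 to compound 4 (0.11 log units; within the scatter), so this position takes the change from 4-ethylphenyl to 4-ethoxyphenyl, and with it one more hydrogen-bond acceptor, without a step beyond the scatter. Across the three aryl analogues, only the two end members separate: compound 4 at 3110 nM and compound 2 at 6590 nM lie beyond the scatter of each other, though neither is separated from compound 3. Nothing on hand gives a cause for the step from ethyl to ethoxy.

From the compounds shown here alone, whether a carboxylic acid, an amine or a longer chain such as butoxy in this place would move the value beyond the scatter stays open. Also open, going by these compounds, is how the same aryl groups behave with any change to the shared core.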